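Growing the methylamino substituent on the shared core

The compounds below may be only part of what the source reports. "The series", "measured", "known", "first", "only" and "open" are said of these compounds alone.

Compound 1, `O=C(Nc1ncc(-c2cccc(Cl)c2)c(-c2ccccc2)n1)C1CCC1`: 52%
Compound 2, `CNc1ncc(-c2cccc(Cl)c2)c(-c2ccccc2)n1`: 75%

Compound 2 stands highest of the two numbers measured in an assay on CHO cells for displacement of a labelled ligand from adenosine receptor A1 (Homo sapiens), read by scintillation counting, with a stated time of 1 h, tested at 1 uM; a higher number here means more inhibition at the concentration tested (going by the name of the read-out), a lower number less inhibition; its nearest neighbour is compound 1, and the step of a number 23 percentage points higher from compound 1 to compound 2 (beyond the scatter) lies beyond the scatter. Compound 3, `CC(C)Nc1ncc(-c2cccc(Cl)c2)c(-c2ccccc2)n1`, has not yet been measured. It differs from compound 2 by isopropyl in place of methyl on a nitrogen on an aromatic ring. Among the measured compounds shown here, only one measured step touches the same place: a number 23 percentage points higher from compound 1 to compound 2 (beyond the scatter), where a cyclobutylcarbonyl gave way to a methyl and the inhibition rose modestly. For the measured compounds named here, no measured pair shows a methyl growing to an isopropyl, so that step offers only indirect guidance that changes at this nitrogen can shift the number. Compound 3 is therefore expected to give 68%, within a range of 48% to 85%, which amounts to an estimated step of a number 7 percentage points lower from compound 2 to compound 3 (within the scatter), not clearly beyond the scatter in either direction.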

Compound 3, a percentage reported as inhibition, at one concentration (the size of the read-out at that concentration, not a potency): 71%
Estimate against measurement, compound 3: 3 percentage points below; the range from low to high includes it.
By their numbers in this assay, from the lowest: compound 1; then compounds 3 and 2 (each within the scatter of the next).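

In this assay, the nitrogen on the aromatic ring carries isopropyl as well as methyl with no clear change in the number: a number 4 percentage points lower from compound 2 to compound 3 (within the scatter). The gap to the amide also holds for the larger group, with a number 19 percentage points higher from compound 1 to compound 3 (beyond the scatter), so among these three compounds, both with a plain alkyl group on this nitrogen stand apart from the one with cyclobutylcarbonyl. Nothing available accounts for either step.

The compounds shown leave open whether the unsubstituted amine or a longer chain such as butylamino would stay level with methylamino and isopropylamino. They also leave open whether a cyclobutyl group directly on the nitrogen, without the carbonyl, would read like the alkyl groups or like the amide.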